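Methoxy in Place of Trifluoromethyl: Compound 2 to Compound 4

The source may hold more compounds than are shown below. What is called first, only, known or untested is meant among the compounds shown, and "the series" means these compounds.

Three compounds have been measured in an assay on isolated protein for inhibition of Amine oxidase [flavin-containing] B (Homo sapiens); a higher number here means a weaker inhibitor, a lower number a stronger inhibitor:

compound 1, `C#CCNC1CCc2c(SCc3ccc4ccccc4c3)cccc21`, 4950 nM
compound 2, `C#CCNC1CCc2c(SCc3ccc(C(F)(F)F)cc3)cccc21`, 9680 nM
compound 3, `C#CCNC1CCc2c(SCCc3cccc(OC)c3)cccc21`, 28700 nM

Compound 2 holds the second highest number of the three. Compound 1 sits nearby, with a number lower by an amount within the usual scatter, so the two cannot be ordered. Compound 3 lies further off, higher by an amount beyond the scatter.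

Compound 4, `C#CCNC1CCc2c(SCc3ccc(OC)cc3)cccc21`, differs from compound 2 in one place: methoxy in place of trifluoromethyl on an aromatic carbon. For the measured compounds named here, no measured pair isolates this exchange, so nothing on hand anchors its size. The step from compound 2 to compound 4 is expected to be small, a 1.2-fold lower number from compound 2 to compound 4 (0.08 log units; within the scatter), likely within the scatter and with no clear direction. Compound 4 is therefore estimated at 8000 nM, with a range from 3000 nM to 25000 nM.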

Compound 4, half-maximal inhibitory concentration: 1900 nM
Estimate against measurement, compound 4: 4.2-fold (0.62 log units) above, and the stated range ends above it.
By their numbers in this assay, from the lowest: compound 4; then compounds 1 and 2 (each within the scatter of the next); then compound 3.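

In this assay, methoxy in place of trifluoromethyl on this aromatic carbon, para to a large group, gives a 5.1-fold lower number from compound 2 to compound 4 (0.71 log units; beyond the scatter). For the compounds shown here, this is the first pair that isolates a single change, and it shows that the group at this place can by itself move the number beyond the scatter. Nothing on hand accounts for the size of this step.

On these data alone, whether a hydroxyl, an amine or a longer alkoxy chain at the same place would lower the number further remains open. Also open, as far as these compounds go, is whether a chloro group would behave more like methoxy or like trifluoromethyl.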